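Swapping Allyloxy for Fluoro on the Shared Core

The source may hold more compounds than are shown below. What is called first, only, known or untested is meant among the compounds shown, and "the series" means these compounds.

Compound 1 `C=CCOc1cc(C2=C(c3cc(OC)c(OC)c(OC)c3)C(=O)C(O)C2)ccc1OC` was tested in an ADME assay on L132 cells (Homo sapiens) for cytotoxicity, read by MTT assay, with a stated time of 72 h; on this read-out higher numbers stand for weaker inhibition and lower numbers for stronger inhibition. In this test compound 1 reaches only a limit of the assay and no number, giving > 100 ug/mL. Compound 2 `COc1ccc(C2=C(c3cc(OC)c(OC)c(OC)c3)C(=O)C(OC(C)=O)C2)cc1OC(C)C` likewise gives just a limit, at > 100 ug/mL. Both results so far sit at the limit of > 100 ug/mL in this assay, at which 2 of the 2 values shown sit, so the numbers say little about how the compounds differ. Compound 3 `COc1ccc(C2=C(c3cc(OC)c(OC)c(OC)c3)C(=O)C(O)C2)cc1F` has not yet been tested; it differs from compound 1 by fluoro in place of allyloxy on an aromatic carbon. Among the measured compounds shown here, with no measured step to lean on, no change beyond the usual scatter is expected, a step that the limit leaves unreadable from compound 1 to compound 3. Compound 3 is therefore estimated to give 150 ug/mL, within 60 ug/mL to 400 ug/mL, most likely again only a limit.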

Compound 3, half-maximal inhibitory concentration: < 1 ug/mL
Compound 3 ended at the assay's limit; the forecaster's own chance of this, stated with the estimate: 80%; middle value at least 150-fold (2.17 log units) away from the limit.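

In this assay, this place on the aromatic ring, ortho to a methoxy group, proves sensitive: fluoro in place of allyloxy gives an at least 100-fold lower number from compound 1 to compound 3 (2.00 log units; beyond the scatter). Compound 1 and compound 2 sat at one shared limit, so they could not show that any change here moves the read-out. Compound 3 gives < 1 ug/mL, which is also a limit and not a number.

Going by these compounds, whether losing allyloxy or gaining fluoro drives the step stays open. So does the result with chloro, a hydroxyl or an amine at this place.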